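Swapping a Nitrophenyl for a Bromohydroxyphenyl Group

This account rests on a few compounds, and the source may have more. Where it says the series, first, only, none or still open, it means among the compounds named here.

Compound 1 `CN(C)C(=O)N(Cc1cccc([N+](=O)[O-])c1)Cc1ccco1` and compound 2 `CCOC(=O)N1CCC(N(Cc2cccc([N+](=O)[O-])c2)C(=O)N(C)C)CC1` share a core that carries a dimethylurea group. In a functional assay on KB cells (Homo sapiens) for antiproliferative activity, read by MTT assay, with a stated time of 48 h (on this read-out higher numbers stand for weaker inhibition and lower numbers for stronger inhibition), compound 1 gives 23800 nM, and compound 2 gives 15600 nM; the two numbers lie within the scatter of each other, so neither can be called stronger. Compound 3 `CCOC(=O)N1CCC(N(Cc2cc(Br)ccc2O)C(=O)N(C)C)CC1` differs from compound 2 in one place: 5-bromo-2-hydroxyphenyl in place of 3-nitrophenyl on a saturated chain carbon bound to an amide-type nitrogen. Going by the values given here, no measured pair here shows what this change does, so a step beyond the scatter in this assay is not expected in either direction. Compound 3 is estimated at 13000 nM, with a range from 4000 nM to 40000 nM, a step of a 1.2-fold lower number from compound 2 to compound 3 (0.08 log units; within the scatter) that is expected to stay within the scatter.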

Compound 3, half-maximal inhibitory concentration: 24600 nM
Compound 3: middle estimate off by 1.9-fold (0.28 log units), on the low side, and the stated range covers the measured number.
By their numbers in this assay, from the lowest: compounds 2, 1 and 3 (each within the scatter of the next).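

In this assay, this swap gives a 1.6-fold higher number from compound 2 to compound 3 (0.20 log units; within the scatter) and so leaves no readable effect on the antiproliferative read-out. At this position, then, a ring with a hydrogen-bond donor and bromine can stand in for the 3-nitrophenyl ring without a measurable difference. No measurement here offers an explanation for this result.

Going by these compounds, the bromine and the hydroxyl enter together, so the share of each stays open. Also open, on these data alone, is whether an amine or a carboxylic acid on this ring would give a step beyond the scatter.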